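The source may report more compounds than this note shows. Statements on the series, on what has been measured and on what is new or still open speak of the compounds shown alone.

Measured so far:
- compound 1, `NC(C(=O)NCC(=O)Nc1ccc(Cl)cc1C(=O)c1ccccc1)c1ccccc1`, with 28 mg/kg in a functional assay on the whole organism for antagonist activity, with Mus musculus as the target; a higher number here means that more compound is needed for the effect, a lower number that less compound is needed
- compound 2, `CCCC(=O)NCC(=O)N(C)c1ccc(Cl)cc1C(=O)c1ccccc1Cl`, with 0.98 mg/kg in this assay

Going by the values given here, compound 2 has the lowest of the two numbers in this assay; the only other value, that of compound 1, is far higher, and the gap lies beyond the scatter of the method. Among the compounds with values here, no single-change step between the two measured compounds exists. They differ in several places at once, so only their two values can be compared.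

Compound 3, `CCC(=O)NCC(=O)N(C)c1ccc(Cl)cc1C(=O)c1ccccc1Cl`, has not been measured yet. It departs from compound 2 at a single spot: hydrogen in place of methyl on a saturated chain carbon, two bonds along the chain from a carbonyl carbon. The shared core is untouched; only the saturated chain on the amide shortens by one carbon.

Within the data shown here, with no measured step to lean on, the expectation is a small change, if any, likely within the scatter, perhaps a slight rise. Compound 3 is estimated at 1.3 mg/kg, within 0.5 mg/kg to 3.5 mg/kg, a step of a 1.3-fold higher number from compound 2 to compound 3 (0.12 log units; within the scatter) that is expected to stay within the scatter.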

Compound 3, dose for half-maximal effect: 1.4 mg/kg
The estimate for compound 3 lay 1.1-fold (0.03 log units) below the measured number; low and high end bracket the measured number.
By their numbers in this assay, from the lowest: compounds 2 and 3 (each within the scatter of the next); then compound 1.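

In this assay, going by these compounds alone, the series now has its first step with only one change: hydrogen replaces methyl on a saturated chain carbon, two bonds along the chain from a carbonyl carbon (a 1.4-fold higher number from compound 2 to compound 3 (0.15 log units; within the scatter)). At this position, a propylcarbonyl group and a propanoyl group therefore cannot be told apart by this measurement, so removing this one carbon has no effect that can be resolved beyond the scatter. Nothing available gives a reason for this result.

On these data alone, it remains open whether a longer chain, a phenyl ring or an amine at this spot would also leave the number within the scatter or would move it clearly. Shortening the chain further, to an acetyl group, is an equally open case.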